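A few compounds are considered here, and "the series" means these few. Any claim that something is new, unique, unknown or untested is made for them only; others in the source may bear on it.

Series notes, coumarin-derived sulfonamide imines.

Compound 1 `CC(C)(C)c1cc(C(C)(C)C)c2oc(=O)c(/C=N/c3ccc(S(N)(=O)=O)cc3)c(Cl)c2c1` is the reference point of the set: in a functional assay on MCF7 cells (Homo sapiens) for cytotoxicity, read by CCK-8 assay, with a stated time of 48 h (on this read-out lower numbers stand for stronger inhibition and higher numbers for weaker inhibition), compound 1 gives 16 nM. Compound 2 `CC(C)(C)c1cc(C(C)(C)C)c2oc(=O)c(/C=N/c3ccc(S(=O)(=O)Nc4nccs4)cc3)c(Cl)c2c1` carries 1,3-thiazol-2-yl in place of hydrogen on a sulfonamide nitrogen and in this assay compound 2 gives 12 nM. The step of a 1.3-fold lower number from compound 1 to compound 2 (0.12 log units; within the scatter) is small, so the two values are not ordered against each other.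

Compound 3 `Cc1ccc2oc(=O)c(/C=N/c3ccc(S(N)(=O)=O)cc3)c(Cl)c2c1` has a different core; how the core of compound 3 differs from the core of compound 1 is not broken down here. In this assay compound 3 gives 270 nM, the highest number of the three measured compounds and beyond the scatter from both compound 1 and compound 2.

Compound 4 `Cc1ccc2oc(=O)c(/C=N/c3ccc(S(=O)(=O)Nc4nccs4)cc3)c(Cl)c2c1` stands to compound 3 as compound 2 stands to compound 1: the change is 1,3-thiazol-2-yl in place of hydrogen on a sulfonamide nitrogen, and the place description is the same word for word as for the change from compound 1 to compound 2, so this is the same change on a second core. Within the data shown here, the only evidence for its effect is the single pair on the first core, where a 1.3-fold lower number from compound 1 to compound 2 (0.12 log units; within the scatter) lies within the scatter.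

On that basis the step of a 1.2-fold lower number from compound 3 to compound 4 (0.09 log units; within the scatter) is expected to be small as well, matching a 1.3-fold lower number from compound 1 to compound 2 (0.12 log units; within the scatter) in direction and size. Among the measured compounds shown here, for compound 4 the expected value in this assay is 220 nM, with a likely range from 100 nM to 500 nM, resting on the value of compound 3, 270 nM, and on the single prior step.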

Compound 4, half-maximal inhibitory concentration: 33 nM
For compound 4 the middle estimate is 6.7-fold (0.82 log units) above the measured one; the measured number lies below the stated range.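

In this assay, 1,3-thiazol-2-yl in place of hydrogen on the sulfonamide nitrogen gives an 8.2-fold lower number from compound 3 to compound 4 (0.91 log units; beyond the scatter) on the core of compound 3, whereas the same change on the core of compound 1 gives no readable step. With only these two pairs, the result does not show which part of the core difference goes with the larger step, nor why the two steps differ, and it gives no rule for what this change would do on a third core. It does show that, in this series, the size of the change measured on one core cannot simply be carried over to another, as the two steps differ by more than the scatter: the same change on two cores in this assay, a 1.3-fold lower number (0.12 log units; within the scatter) from compound 1 to compound 2 and an 8.2-fold lower number (0.91 log units; beyond the scatter) from compound 3 to compound 4, 6.1-fold (0.79 log units) apart, beyond the scatter of two such steps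

Still open, as far as these compounds go, is whether a core lying between those of compound 1 and compound 3 gives a step closer to the first pair or to the second. Also open, from the compounds shown here alone, is whether other groups on the sulfonamide nitrogen, such as methyl, acetyl or pyridin-2-yl, follow 1,3-thiazol-2-yl on both cores, or whether the larger step on the core of compound 3 is peculiar to that ring.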